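Dropping the Oxolane Ring from Compound 2

The source may report more compounds than this note shows. Statements on the series, on what has been measured and on what is new or still open speak of the compounds shown alone.

- Compound 1 `Cc1cc(C)c(CN2CCc3c(Cl)cc([C@H](CO)[C@H]4CCOC4)c(Cl)c3C2=O)c(=O)[nH]1`: 2
- Compound 2 `Cc1cc(C)c(CN2CCc3c(Cl)cc([C@H](CO)[C@H]4CCCO4)c(Cl)c3C2=O)c(=O)[nH]1`: 2.1

In a physicochemical assay for lipophilicity, at pH 7.4 (a higher number here means a more lipophilic compound, a lower number a more polar compound), these two compounds lie within the scatter of each other, so compound 2 stands level with compound 1 and not clearly apart from it. Among the compounds with values here, the only measured step, a number 0.10 log units higher from compound 1 to compound 2 (within the scatter), moves the point of attachment on the oxolane ring, but the ring itself stays.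

Compound 3 `Cc1cc(C)c(CN2CCc3c(Cl)cc([C@H](C)CO)c(Cl)c3C2=O)c(=O)[nH]1` has not yet been measured, and its change is larger. Relative to compound 2, it carries a group of 4 heavy atoms (3 carbon, 1 oxygen; no ring) in place of a group of 8 heavy atoms (6 carbon, 2 oxygen; one five-membered non-aromatic ring with 1 hetero atom), on an aromatic carbon. The entering 1-(hydroxymethyl)ethyl group has no ring.

Within the data shown here, the one measured step therefore offers only a loose guide. Among the measured compounds shown here, it shows that moving the ring's attachment changes this assay by no more than the scatter, but no measured pair shows what losing the ring does. A small upward step is expected, though it may not clear the scatter, and the uncertainty is wide. The expected change is a number 0.20 log units higher from compound 2 to compound 3 (within the scatter). For compound 3, the estimated value is 2.3, with an expected range from 1.9 to 2.7.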

Compound 3, distribution coefficient: 2.6
The estimate for compound 3 lay 0.30 log units below the measured number; the measured number falls inside the stated range.
By their numbers in this assay, from the lowest: compounds 1 and 2 (each within the scatter of the next); then compound 3.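

In this assay, putting 1-(hydroxymethyl)ethyl on the aromatic carbon in place of the oxolane-bearing group gives a number 0.50 log units higher from compound 2 to compound 3 (beyond the scatter), and the same kind of replacement gives a number 0.60 log units higher from compound 1 to compound 3 (beyond the scatter). Within the data shown here, the earlier pair showed only that moving the ring's attachment from oxolan-3-yl to oxolan-2-yl gives a number 0.10 log units higher from compound 1 to compound 2 (within the scatter), so in these three compounds, having the ring at all counts for more in this reading than where it is attached, and both ring-bearing compounds go the same way when it leaves. Nothing available explains why the number rises with this replacement.

The replacement removes the ring and the ring oxygen in one step, and the compounds shown cannot separate what each of these contributes to the change. From the compounds shown here alone, it also remains open where this reading would fall with an all-carbon cyclopentyl ring in place of the oxolane, or with an open ether chain that keeps the oxygen but has no ring.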